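Swapping the cinnamoyl arm of a tellurium-bearing amide

This account rests on a few compounds, and the source may have more. Where it says the series, first, only, none or still open, it means among the compounds named here.

Measured compounds:
compound 1, `COc1ccc(N(CC(=O)NCCC[Te]c2ccccc2)C(=O)/C=C/c2ccccc2)cc1`, 6000 nM
compound 2, `COc1ccc(N(CC(=O)NCCC[Se]c2ccccc2)C(=O)/C=C/c2ccccc2)cc1`, >= 100000 nM
compound 3, `COc1ccc(N(CC(=O)NCCCSc2ccccc2)C(=O)/C=C/c2ccccc2)cc1`, >= 100000 nM

Three compounds share a core and differ only in the chalcogen that links a phenyl ring to the saturated chain. Within the data shown here, in a functional assay on A-431 cells (Homo sapiens) for cytotoxicity, read by MTT assay, with a stated time of 24 h (on this read-out higher numbers stand for weaker inhibition and lower numbers for stronger inhibition), compound 1 gives 6000 nM, the only number among the three values. Compound 2 reaches only the limit of this assay, >= 100000 nM. Compound 3 likewise stops at the limit, >= 100000 nM. The steps of an at least 16-fold higher number from compound 1 to compound 2 (1.22 log units; beyond the scatter) and an at least 16-fold higher number from compound 1 to compound 3 (1.22 log units; beyond the scatter) thus both run against (the limit of >= 100000 nM in this assay, at which 2 of the 3 values shown sit), and the step that the two limits leave unreadable from compound 2 to compound 3 cannot be read.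

Compound 4, `COc1ccc(N(CC(=O)NCCC[Te]c2ccccc2)C(=O)CNC(=O)OC(C)(C)C)cc1`, keeps the tellurium arm of compound 1 and instead changes the other side of the amide nitrogen: ((tert-butoxycarbonyl)amino)methyl in place of 2-phenylethenyl on a carbonyl carbon. Among the measured compounds shown here, none of the measured steps touches this position, so they offer no direct guide; they show only that the tellurium arm, which compound 4 retains, goes with the one readable number. The expectation is therefore that compound 4 stays in the measurable range but with wide uncertainty, with an estimated step of a 2.5-fold higher number from compound 1 to compound 4 (0.40 log units; beyond the scatter). Compound 4 is estimated at 15000 nM, within 3000 nM to 100000 nM.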

Compound 4, half-maximal inhibitory concentration in the A-431 assay: 5000 nM
Compound 4: the middle estimate sits 3.0-fold (0.48 log units) above what was measured; low and high end bracket the measured number.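

In the A-431 assay, ((tert-butoxycarbonyl)amino)methyl in place of 2-phenylethenyl on a carbonyl carbon gives a 1.2-fold lower number from compound 1 to compound 4 (0.08 log units; within the scatter), so the effect of this change cannot be told from the scatter. This position, which none of the chalcogen steps touched, therefore accepts a group with no ring, and with a hydrogen-bond donor and hydrogen-bond acceptors that 2-phenylethenyl lacks, while the cytotoxicity reading holds. The same change separates the two compounds clearly in a physicochemical assay for lipophilicity, read by HPLC, measured as octanol-water partition; on this read-out lower numbers stand for lower lipophilicity and higher numbers for higher lipophilicity: compound 1 gives 1.31, while compound 4 gives 4.2, so a gap beyond the scatter there comes with no readable change in the A-431 assay.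

As far as these compounds go, what remains open is whether the carbonyl carbon accepts almost any group or only these two, which an aminomethyl group, a carboxylic acid or a longer chain at the same place would help to settle. From the compounds shown here alone, it is also open whether ((tert-butoxycarbonyl)amino)methyl would give the same result with selenium or sulfur in place of tellurium, as in the arms of compound 2 and compound 3.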